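The compounds below may be only part of what the source reports. "The series", "measured", "known", "first", "only" and "open" are said of these compounds alone.

Measured so far in an ADME assay on HEK-293T cells (Homo sapiens) for cytotoxicity, read by CCK-8 assay, with a stated time of 48 h; a higher number here means a weaker inhibitor, a lower number a stronger inhibitor:
- Compound 1 `O=S(=O)(NCCNC(=S)Nc1cc(C(F)(F)F)cc(C(F)(F)F)c1)c1ccc(-c2ccccc2OCc2cccc(O)c2)s1`: > 20000 nM, a limit
- Compound 2 `COc1ccc(Oc2ccc(C(C)C)cc2-c2ccsc2S(=O)(=O)NCCNC(=O)Nc2cc(Cl)cc(Cl)c2)cc1OC`: 11900 nM
- Compound 3 `O=S(=O)(NCCNC(=S)Nc1cc(C(F)(F)F)cc(C(F)(F)F)c1)c1ccc(-c2ccccc2O[C@H]2CC[C@@H](O)CC2)s1`: > 20000 nM, a limit

Compound 3 has no number of its own, only (the limit of > 20000 nM in this assay, at which 2 of the 3 values shown sit). Compound 2 is the only one of the three with a true number.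

Compound 4 `O=S(=O)(NCCNC(=S)Nc1cc(C(F)(F)F)cc(C(F)(F)F)c1)c1ccc(-c2ccccc2OCc2ccccc2)s1` has benzyl in place of 4-hydroxycyclohexyl on an oxygen on an aromatic ring. A six-membered non-aromatic ring of carbon gives way to a six-membered aromatic ring of carbon, and the hydrogen-bond donor and acceptor of the leaving group are lost.

Going by the values given here, only one measured step changes the group on this oxygen: a step that the two limits leave unreadable from compound 1 to compound 3. Both its ends are limits, so it offers no size to carry over. No step beyond the usual scatter is therefore expected in this assay, and these data favour neither direction. The expected step is a number no higher from compound 3 to compound 4 (the limit leaves the size open), and this too may turn out to be only a limit. Going by these compounds, the range stays open on the low side since compound 2 gives 11900 nM. For compound 4 the expected value is 20000 nM, with an estimated range from 10000 nM to 40000 nM.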

Compound 4, half-maximal inhibitory concentration: 8500 nM
For compound 4 the middle estimate is 2.4-fold (0.37 log units) above the measured one; measured number below the stated range.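

In this assay, the group on this oxygen now shows a readable effect, which the earlier pair with limits at both ends could not show. Benzyl in place of 4-hydroxycyclohexyl gives an at least 2.3-fold lower number from compound 3 to compound 4 (0.37 log units; beyond the scatter), and hydrogen in place of the hydroxy on the aromatic carbon of the 3-hydroxybenzyl group gives an at least 2.3-fold lower number from compound 1 to compound 4 (0.37 log units; beyond the scatter), so among compounds 1, 3 and 4 only the group without a hydroxy gives a true number. Both steps give only a minimum size, because each starts from a limit: the limit of > 20000 nM in this assay, at which 2 of the 4 values shown sit.

The step between compound 1 and compound 3 cannot be read, so the 3-hydroxybenzyl and 4-hydroxycyclohexyl groups cannot be ranked against each other. Going by these compounds, whether the lower number of compound 4 follows from losing the hydroxy or from having the aromatic ring remains open, and a plain cyclohexyl on this oxygen would separate the two, while an amine in place of the hydroxy on the benzyl group would test whether another group there behaves like the hydroxy.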